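The compounds below may be only part of what the source reports. "The series", "measured", "known", "first", "only" and "open" are said of these compounds alone.

Measured so far in an assay on CHO cells for displacement of a labelled ligand from adenosine receptor A1 (Homo sapiens), read by scintillation counting, with a stated time of 3 h; a lower number here means a stronger inhibitor, a higher number a weaker inhibitor:
compound 1 `Cn1c(-c2cccc(Cl)c2)nc2c(NC3CCCC3)ncnc21` gives 6.5 nM;
compound 2 `Cc1ccc(-c2nc3c(NC4CCCC4)ncnc3n2C)cc1` gives 8 nM;
compound 3 `Cn1c(-c2ccccc2Cl)nc2c(NC3CCCC3)ncnc21` gives 37 nM.

Compound 3 stands highest of these three numbers. Its distance from compound 1 is a 5.7-fold higher number from compound 1 to compound 3 (0.76 log units; beyond the scatter) and its distance from compound 2 is a 4.6-fold higher number from compound 2 to compound 3 (0.67 log units; beyond the scatter), both beyond the scatter, whereas the step of a 1.2-fold higher number from compound 1 to compound 2 (0.09 log units; within the scatter) lies within the scatter, so compound 1 and compound 2 cannot be ordered against each other.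

Compound 4 `Cn1c(-c2ccc(Cl)cc2)nc2c(NC3CCCC3)ncnc21` is the next compound to be tested. It differs from compound 3 by 4-chlorophenyl in place of 2-chlorophenyl on an aromatic carbon. The measured steps that bear on this change are the two that reach compound 3: a 5.7-fold higher number from compound 1 to compound 3 (0.76 log units; beyond the scatter) and a 4.6-fold higher number from compound 2 to compound 3 (0.67 log units; beyond the scatter). Each shows that the 2-chlorophenyl of compound 3 carries a modestly higher number than either of the other two single substituents on that ring, and compound 2, which bears a 4-methylphenyl at the same place, sits among the lower numbers. Compound 4 is therefore expected to move back toward those lower numbers, with a step of about a 4.1-fold lower number from compound 3 to compound 4 (0.61 log units; beyond the scatter) in this assay. Compound 4 is estimated at 9 nM, with an expected range from 3 nM to 30 nM.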

Compound 4, inhibition constant: 18 nM
The estimate for compound 4 lay 2.0-fold (0.30 log units) below the measured number, within the range that was stated.
By their numbers in this assay, from the lowest: compounds 1 and 2 (each within the scatter of the next); then compound 4; then compound 3.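

With the 4-chlorophenyl in place, this assay now covers three chlorophenyl isomers at this aromatic carbon, and the step of a 2.1-fold lower number from compound 3 to compound 4 (0.31 log units; beyond the scatter) shows that moving away from the 2-chlorophenyl gives a lower number even when the new group is not the 3-chlorophenyl. The recovery is only partial, since the step of a 2.8-fold higher number from compound 1 to compound 4 (0.44 log units; beyond the scatter) lies beyond the scatter, so the 3-chlorophenyl and the 4-chlorophenyl can now be told apart and the three isomers fall in the order 3-chlorophenyl, 4-chlorophenyl, 2-chlorophenyl, from the lowest number to the highest. The step of a 2.3-fold higher number from compound 2 to compound 4 (0.35 log units; beyond the scatter) adds that the choice of group on the phenyl ring also counts, as chloro in place of methyl changes the number beyond the scatter. Nothing given here accounts for any of these differences.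

As far as these compounds go, whether the 2-methylphenyl and 3-methylphenyl would follow the same order as the chlorophenyl isomers remains open. So does the standing of a methoxy, a nitrile or an amine on the phenyl ring, or of a ring carrying two chloro groups.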